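The source may hold more compounds than are shown below. What is called first, only, known or untested is meant among the compounds shown, and "the series" means these compounds.

Measured so far in an ADME assay (Homo sapiens) for cytotoxicity; on this read-out lower numbers stand for higher toxicity in this test and higher numbers for lower toxicity in this test: compound 1 `CC(=O)N1CCC(C(=O)N(CCCN2CCN(Cc3cnc(Cl)s3)CC2)c2ccc(C)c(Cl)c2)CC1` gives > 52300 nM, which is a limit of the assay. Compound 2 `CC(=O)N1CCC(C(=O)N(CCCN2CCN(Cc3ccc(C#N)cc3)CC2)c2ccc(C)c(Cl)c2)CC1` gives > 100000 nM, also a limit.

Within the data shown here, compound 2 therefore stands at the limit of > 100000 nM in this assay, at which 1 of the 2 values shown sits, while the only other value sits at the limit of > 52300 nM in this assay, at which 1 of the 2 values shown sits. The step that the two limits leave unreadable from compound 1 to compound 2 cannot be read from the two limits. Compound 3 `CC(=O)N1CCC(C(=O)N(CCCN2CCN(Cc3ccccc3)CC2)c2ccc(C)c(Cl)c2)CC1` differs from compound 2 by hydrogen in place of cyano on an aromatic carbon. Among the measured compounds shown here, no measured step bears readably on this change, so no move beyond the scatter is expected. Compound 3 is estimated at 100000 nM, in a range from 30000 nM to 300000 nM. The expected step is a number no higher from compound 2 to compound 3 (the limit leaves the size open).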

Compound 3, half-maximal cytotoxic concentration: 101000 nM
Beside the measured number, compound 3's estimate is 1.0-fold (0.00 log units) below it, and the stated range covers the measured number.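

In this assay, the steps to compound 3 from compound 1 and compound 2 cannot be read: both of those compounds carry only limits. From the compounds shown here alone, whether phenyl, 4-cyanophenyl and 2-chloro-1,3-thiazol-5-yl differ in this read-out stays open.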